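Notes on a furan for phenyl swap in one series

A few compounds are considered here, and "the series" means these few. Any claim that something is new, unique, unknown or untested is made for them only; others in the source may bear on it.

Measured in a functional assay on TE-1 cells (Homo sapiens) for antiproliferative activity, read by MTT assay, with a stated time of 72 h; on this read-out lower numbers stand for stronger inhibition and higher numbers for weaker inhibition:
compound 1 `CCCSc1nc(Cl)c2c(n1)N(Cc1ccccc1)C(C(=O)N1CCN(Cc3ccccc3)CC1)N2` gives 48200 nM
compound 2 `CCCSc1nc(Cl)c2c(n1)N(Cc1cccs1)C(C(=O)N1CCN(C)CC1)N2` gives 39400 nM
compound 3 `CCCSc1nc(Cl)c2c(n1)N(Cc1ccccc1)C(C(=O)N1CCN(C)CC1)N2` gives 42500 nM

Compound 3 sits between the other two numbers, and both its neighbours lie within the scatter of it: a 1.1-fold lower number from compound 1 to compound 3 (0.05 log units; within the scatter) and a 1.1-fold higher number from compound 2 to compound 3 (0.03 log units; within the scatter). The three numbers therefore cannot be ranked.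

Compound 4 `CCCSc1nc(Cl)c2c(n1)N(Cc1ccco1)C(C(=O)N1CCN(C)CC1)N2` differs from compound 3 in one place: furan-2-yl in place of phenyl on a saturated chain carbon bound to a nitrogen on an aromatic ring in a ring. Among the compounds with values here, the only step that bears directly on this place is a 1.1-fold higher number from compound 2 to compound 3 (0.03 log units; within the scatter), where one five-membered aromatic ring with a hetero atom was exchanged for phenyl at the same carbon without any movement beyond the scatter. The step of a 1.1-fold lower number from compound 1 to compound 3 (0.05 log units; within the scatter) touches a different place and says nothing about this one. With a single relevant step of that size, no movement beyond the scatter is expected in this assay for compound 4, in either direction, and the step of a 1.0-fold lower number from compound 3 to compound 4 (0.02 log units; within the scatter) is the expectation.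

Compound 4 is estimated at 41000 nM, expected range 20000 nM to 85000 nM.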

Compound 4, half-maximal inhibitory concentration: 35000 nM
Estimate against measurement, compound 4: 1.2-fold (0.07 log units) above, and the stated range covers the measured number.
By their numbers in this assay, from the lowest: compounds 4, 2, 3 and 1 (each within the scatter of the next).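

In this assay, furan-2-yl on a saturated chain carbon bound to a nitrogen on an aromatic ring in a ring stays within the scatter of phenyl (a 1.2-fold lower number from compound 3 to compound 4 (0.08 log units; within the scatter)). It also stays within the scatter of thiophen-2-yl (a 1.1-fold lower number from compound 2 to compound 4 (0.05 log units; within the scatter)), so phenyl and the two five-membered aromatic rings cannot be ranked here, and the hydrogen-bond acceptor counted for furan-2-yl brings no movement beyond the scatter. Nothing available accounts for this result.

Still open, on these data alone, is whether a group of another kind at this carbon, such as cyclohexyl, pyridin-2-yl or a propyl chain, would move the number beyond the scatter. Also open, as far as these compounds go, is whether furan-2-yl would read the same in the core of compound 1, which carries the benzyl group on its amide ring.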